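Swapping an amine-linked ring for an ether-linked ring

A few compounds are considered here, and "the series" means these few. Any claim that something is new, unique, unknown or untested is made for them only; others in the source may bear on it.

Compound 1 `CC1(C)CCC(CN2CCN(c3ccc(C(=O)NS(=O)(=O)c4ccc(NCC5CCOCC5)c([N+](=O)[O-])c4)c(Oc4cnc5[nH]ccc5c4)c3)CC2)=C(c2ccc(C(F)(F)F)cc2)C1`: 1.5 nM
Compound 2 `CCN(CC)CCCNc1ccc(S(=O)(=O)NC(=O)c2ccc(N3CCN(CC4=C(c5ccc(C(F)(F)F)cc5)CC(C)(C)CC4)CC3)cc2Oc2cnc3[nH]ccc3c2)cc1[N+](=O)[O-]`: 0.3 nM
Compound 3 `CC1(C)CCC(CN2CCN(c3ccc(C(=O)NS(=O)(=O)c4ccc(NCC5CCOC5)c([N+](=O)[O-])c4)c(Oc4cnc5[nH]ccc5c4)c3)CC2)=C(c2ccc(C(F)(F)F)cc2)C1`: 4.7 nM

In an assay on isolated protein for displacement of a labelled ligand from Apoptosis regulator Bcl-2 (Homo sapiens), with a stated time of 15 min (on this read-out higher numbers stand for weaker inhibition and lower numbers for stronger inhibition), compound 3 gives the highest number of the three, so it is the weakest of this set. Compound 4 `CC1(C)CCC(CN2CCN(c3ccc(C(=O)NS(=O)(=O)c4ccc(OCC5CCOCC5)c([N+](=O)[O-])c4)c(Oc4cnc5[nH]ccc5c4)c3)CC2)=C(c2ccc(C(F)(F)F)cc2)C1` differs from it in one place: (oxan-4-yl)methoxy in place of ((oxolan-3-yl)methyl)amino on an aromatic carbon. Part of this change, the five-membered ring giving way to the six-membered one, has a measured counterpart: a 3.1-fold higher number from compound 1 to compound 3 (0.50 log units; beyond the scatter), a modest shift, so running it the other way should lower the number by about that much. Among the compounds with values here, the second part, the amine link giving way to an ether link, has no measured counterpart here; the remaining step, a 16-fold higher number from compound 2 to compound 3 (1.19 log units; beyond the scatter), concerns a different group and does not speak to it. The expectation for compound 4 is therefore a modest step down from compound 3, near the number of compound 1, expressed as a 1.9-fold lower number from compound 3 to compound 4 (0.27 log units; within the scatter). Compound 4 is estimated at 2.5 nM in this assay, with a range from 0.8 nM to 8 nM.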

Compound 4, half-maximal inhibitory concentration: 1 nM
Beside the measured number, compound 4's estimate is 2.5-fold (0.40 log units) above it, and the stated range covers the measured number.
By their numbers in this assay, from the lowest: compound 2; then compounds 4 and 1 (each within the scatter of the next); then compound 3.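

The clearest reading of this change is a 1.5-fold lower number from compound 1 to compound 4 (0.18 log units; within the scatter) with only the link altered, since the oxan-4-yl ring stays in place: on this aromatic carbon ortho to a nitro group, an oxygen link without a hydrogen-bond donor does as well as the amino link, within the scatter. The larger 4.7-fold lower number from compound 3 to compound 4 (0.67 log units; beyond the scatter) also involves a six-membered ring replacing a five-membered one, so among these compounds it follows the ring rather than the link. The (3-(diethylamino)propyl)amino group of compound 2 still gives the lowest number, seen in a 3.3-fold higher number from compound 2 to compound 4 (0.52 log units; beyond the scatter) as the step up to the ether.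

Why the ring size or the side chain shifts the number has no measurement behind it here.

Still open, going by these compounds, is whether a sulfur link, or an oxygen link carrying the same diethylamino chain, would match these values.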